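Changing the amide side chain of compound 3

The source may report more compounds than this note shows. Statements on the series, on what has been measured and on what is new or still open speak of the compounds shown alone.

Compound 1 `Cn1ccc2ccc(-c3cc(Nc4cnccc4C(=O)NCc4cncnc4)cc4nccnc34)cc21`: 0.4 h
Compound 2 `Cn1cc(CNC(=O)c2ccncc2Nc2cc(-c3ccc4ccn(C)c4c3)c3nccnc3c2)cn1`: 0.267 h
Compound 3 `CC(=O)N1CCCC(NC(=O)c2ccncc2Nc2cc(-c3ccc4ccn(C)c4c3)c3nccnc3c2)C1`: 0.4 h

In an ADME assay on microsomes from liver (Mus musculus, strain CD-1) for metabolic stability, read by LC-MS, tested at 2 uM (a higher number here means that the compound lasts longer, a lower number that the compound disappears faster), compound 3 gives 0.4 h, level with compound 1 at the digits shown, and compound 2 stays within the scatter of both. Compound 4 `CC(=O)N1CC(CNC(=O)c2ccncc2Nc2cc(-c3ccc4ccn(C)c4c3)c3nccnc3c2)C1` carries (1-acetylazetidin-3-yl)methyl in place of 1-acetylpiperidin-3-yl on an amide-type nitrogen. The measured steps that change the group on this nitrogen are small: a 1.5-fold lower number from compound 1 to compound 2 (0.18 log units; within the scatter), no change at the digits printed from compound 1 to compound 3 (within the scatter) and a 1.5-fold higher number from compound 2 to compound 3 (0.18 log units; within the scatter). On these steps, no change beyond the scatter is expected in this assay, in either direction. The expected step is a 1.1-fold lower number from compound 3 to compound 4 (0.05 log units; within the scatter). Compound 4 is estimated at 0.36 h, with a range of 0.2 h to 0.65 h.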

Compound 4, half-life: > 1 h
Compound 4 gave a limit, no number; the forecaster's own chance of this, stated with the estimate: 5%; middle value at least 2.7-fold (0.44 log units) from the limit.
By their numbers in this assay, from the lowest: compounds 2, 1 and 3 (each within the scatter of the next). At a limit, above all of these: compound 4.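

In this assay compound 4 gives a limit and not a number: the limit of > 1 h in this assay, at which 1 of the 4 values shown sits. Going by these compounds alone, its (1-acetylazetidin-3-yl)methyl group gives the first steps at this amide-type nitrogen that lie beyond the scatter: an at least 2.5-fold higher number from compound 3 to compound 4 (0.39 log units; beyond the scatter), an at least 2.5-fold higher number from compound 1 to compound 4 (0.39 log units; beyond the scatter) and an at least 3.7-fold higher number from compound 2 to compound 4 (0.57 log units; beyond the scatter). Compounds 1, 2 and 3 had stayed within the scatter of one another, so the group on this nitrogen can matter after all.

On these data alone, the true size of these steps remains unknown. As far as these compounds go, the change from compound 3 to compound 4 alters both ring and chain, so it remains open whether (1-acetylpiperidin-3-yl)methyl, or an amine in place of the acetyl group, would behave like compound 4.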